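Adding a Hydroxy Group to the Phenyl of Compound 2

The source may hold more compounds than are shown below. What is called first, only, known or untested is meant among the compounds shown, and "the series" means these compounds.

Three hydroxamic acids sharing one core have been measured in an assay on Sf9 cells for inhibition of protein deacetylase HDAC6 (Homo sapiens), read by fluorescence, with a stated time of 40 min; on this read-out lower numbers stand for stronger inhibition and higher numbers for weaker inhibition. Compound 1 `Cc1ccc(-c2nc(CNc3ccc(C(=O)NO)cc3)n(-c3ccccc3)n2)cc1` gives 224 nM. Compound 2 `COc1ccc(-n2nc(-c3ccccc3)nc2CNc2ccc(C(=O)NO)cc2)cc1` gives 127 nM, and compound 3 `Cc1ccc(-n2nc(-c3ccccc3)nc2CNc2ccc(C(=O)NO)cc2)cc1` gives 310 nM. Compound 2 therefore has the lowest of the three numbers, yet compound 1 sits within the scatter of it, so the two cannot be ranked; only compound 3 is set apart, through the step of a 2.4-fold higher number from compound 2 to compound 3 (0.39 log units; beyond the scatter).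

The next compound, compound 4 `COc1ccc(-n2nc(-c3ccc(O)cc3)nc2CNc2ccc(C(=O)NO)cc2)cc1`, differs from compound 2 by hydroxy in place of hydrogen on an aromatic carbon. For the measured compounds named here, this change touches the phenyl ring, whereas the only step measured so far, from compound 2 to compound 3, concerns the other aromatic ring, where methyl replaces methoxy. Going by the values given here, no measured pair therefore speaks directly to a hydroxy on the phenyl, and nothing in the data points to a shift in one direction or the other. The expected step is accordingly a 1.1-fold higher number from compound 2 to compound 4 (0.04 log units; within the scatter), not beyond the scatter. Compound 4 is estimated at 140 nM, with a range from 60 nM to 330 nM, reflecting the absence of a guiding precedent rather than any expected gain or loss.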

Compound 4, half-maximal inhibitory concentration: 102 nM
The estimate for compound 4 lay 1.4-fold (0.14 log units) above the measured number; the range from low to high includes it.
By their numbers in this assay, from the lowest: compounds 4, 2, 1 and 3 (each within the scatter of the next, the first and the last beyond it).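

For the compounds shown here, the change from phenyl to 4-hydroxyphenyl is the first one in this set made on this ring of the shared core, and in this assay it gives only a small step (a 1.2-fold lower number from compound 2 to compound 4 (0.10 log units; within the scatter)), so compound 2 and compound 4 cannot be ranked against each other. This shows that, at least on the core of compound 2, this carbon para to a large group can carry a hydroxy, with its hydrogen-bond donor and acceptor, without any shift that stands clear of the usual scatter of the measurement. Nothing among the available data helps to explain why this exchange leaves the number within the scatter.

From the compounds shown here alone, only hydrogen and hydroxy can be compared at this place, so it remains open whether a larger or charged group, such as an amine, a carboxylic acid or a longer alkoxy chain, would also leave the number within the scatter. Going by these compounds, it is also open whether the same hydroxy would have as small an effect in compound 3, where methyl replaces methoxy on the other aromatic ring, or on the differently arranged core of compound 1.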